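This account rests on a few compounds, and the source may have more. Where it says the series, first, only, none or still open, it means among the compounds named here.

Measured in a functional assay, with a stated time of 10 min; a higher number here means a weaker inhibitor, a lower number a stronger inhibitor:
- Compound 1 `CCOC(=O)c1cnn(-c2nc(-c3ccccc3F)c(C#N)c(=O)n2C)c1N`: 86 ug/mL
- Compound 2 `Cn1c(NN)nc(-c2cccs2)c(C#N)c1=O`: 53 ug/mL

Only these two compounds have been measured so far, and their values lie within the usual scatter of each other. For the measured compounds named here, compound 1 therefore cannot be ranked against compound 2, and it sits level with the only other number available.

Compound 3 `CCOC(=O)c1cnn(-c2nc(-c3cccs3)c(C#N)c(=O)n2C)c1N` keeps the core of compound 1 but carries thiophen-2-yl in place of 2-fluorophenyl, on an aromatic carbon ortho to a cyano group (thiophen-2-yl in place of 2-fluorophenyl on an aromatic carbon). Going by the values given here, no measured pair shows what this exchange does in this assay, so the expectation rests on thin ground. Compound 2, which also bears thiophen-2-yl, gives 53 ug/mL, and this points at most to a slightly lower number than that of compound 1. The expected change is a 1.2-fold lower number from compound 1 to compound 3 (0.09 log units; within the scatter), an estimated step that does not go beyond the scatter. For compound 3 the estimated value is 70 ug/mL, with an expected range from 35 ug/mL to 140 ug/mL.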

Compound 3, half-maximal inhibitory concentration: 109 ug/mL
Estimate against measurement, compound 3: 1.6-fold (0.19 log units) below, and the stated range covers the measured number.
By their numbers in this assay, from the lowest: compounds 2, 1 and 3 (each within the scatter of the next, the first and the last beyond it).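

In this assay, for the compounds shown here, the exchange of 2-fluorophenyl for thiophen-2-yl, on an aromatic carbon ortho to a cyano group, gives a 1.3-fold higher number from compound 1 to compound 3 (0.10 log units; within the scatter) and is the first direct reading of a change at this position. A six-membered aromatic ring of carbon only and a five-membered aromatic ring with 1 hetero atom therefore cannot be told apart here when the rest of compound 1 stays the same, so this single exchange gives no sign that the choice between these two groups matters in this assay. No measurement offers an explanation for this result.

The compounds shown leave open whether any other group at this aromatic carbon, such as an unsubstituted phenyl, a furan-2-yl, a morpholine or a simple amine, would move the number beyond the scatter. Going by these compounds alone, they also leave open whether this position matters at all, as the only exchange read here joins two aromatic rings and a single pair cannot establish a wider pattern.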